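A few compounds are considered here, and "the series" means these few. Any claim that something is new, unique, unknown or untested is made for them only; others in the source may bear on it.

Three compounds of the series have numbers in a functional assay on cells (Pituitary gland cell) for antagonist activity at Gonadotropin-releasing hormone receptor (Rattus norvegicus); on this read-out higher numbers stand for weaker inhibition and lower numbers for stronger inhibition. Compound 1 `Cc1cc(-c2c(O)nc3cc(Cl)c([N+](=O)[O-])cc3c2OCCC2CCCCN2)cc(C(C)O)c1` gives 63 nM, compound 2 `Cc1ccc(-c2c(O)nc3cc(Cl)c([N+](=O)[O-])cc3c2OCCC2CCCCN2)c(C)c1` gives 400 nM, and compound 3 `O=[N+]([O-])c1cc2c(OCCC3CCCCN3)c(-c3ccccc3Cl)c(O)nc2cc1Cl` gives 360 nM. Compound 3 stands second highest of the three: a 1.1-fold lower number from compound 2 to compound 3 (0.05 log units; within the scatter), whereas a 5.7-fold higher number from compound 1 to compound 3 (0.76 log units; beyond the scatter). Compound 4 `CC(=O)OCc1cc(C)cc(-c2c(O)nc3cc(Cl)c([N+](=O)[O-])cc3c2OCCC2CCCCN2)c1` differs from compound 3 by 3-(acetoxymethyl)-5-methylphenyl in place of 2-chlorophenyl on an aromatic carbon. The step that bears on this change is a 5.7-fold higher number from compound 1 to compound 3 (0.76 log units; beyond the scatter), read in reverse, as the 3-(acetoxymethyl)-5-methylphenyl of compound 4 resembles the 3-(1-hydroxyethyl)-5-methylphenyl of compound 1; a 6.3-fold higher number from compound 1 to compound 2 (0.80 log units; beyond the scatter) shows a comparable size for the other replacement. A downward step of similar size is therefore expected, a 4.5-fold lower number from compound 3 to compound 4 (0.65 log units; beyond the scatter). Compound 4 is expected to give about 80 nM in this assay, with a range from 30 nM to 250 nM.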

Compound 4, half-maximal inhibitory concentration: 45 nM
Estimate against measurement, compound 4: 1.8-fold (0.25 log units) above; low and high end bracket the measured number.
By their numbers in this assay, from the lowest: compounds 4 and 1 (each within the scatter of the next); then compounds 3 and 2 (each within the scatter of the next).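

In this assay, 3-(acetoxymethyl)-5-methylphenyl in place of 2-chlorophenyl gives an 8.0-fold lower number from compound 3 to compound 4 (0.90 log units; beyond the scatter), and in place of 2,4-dimethylphenyl it gives an 8.9-fold lower number from compound 2 to compound 4 (0.95 log units; beyond the scatter). The low numbers at this position are therefore no longer tied to 3-(1-hydroxyethyl)-5-methylphenyl alone. Acetoxymethyl in place of 1-hydroxyethyl gives a 1.4-fold lower number from compound 1 to compound 4 (0.15 log units; within the scatter), so the two groups are not told apart here.

Open, going by these compounds, is whether a carboxylic acid or an amine in that place would give similar numbers, and whether the 5-methyl group is needed. No data at hand account for these steps.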